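The compounds below may be only part of what the source reports. "The series", "measured", "known", "first", "only" and "open" are said of these compounds alone.

Measured in a functional assay on the whole organism with Rattus norvegicus as the target, at a dose of 40 mg/kg by the intraperitoneal route; on this read-out higher numbers stand for more inhibition at the one dose given (going by the name of the read-out) and lower numbers for less inhibition:
compound 1, `CC(C)c1nc2c(OCc3ccccc3)cccn2c1N`, gives 0%
compound 2, `Cc1nc2c(OCc3ccc(Cl)cc3)cccn2c1N`, gives 66%
compound 3, `Cc1nc2c(OCc3ccccc3)cccn2c1CN`, gives 46%

Compound 3 stands second highest of these three numbers: compound 2 lies higher by a gap beyond the usual scatter, and compound 1 lies far lower, also beyond the scatter. Compound 4, `CNC(=O)Nc1c(C)nc2c(OCc3ccccc3)cccn12`, has not yet been measured. It differs from compound 3 in one place: (methylcarbamoyl)amino in place of aminomethyl on an aromatic carbon. For the measured compounds named here, no pair of measured compounds differs in just one place, so no measured step gives the size of this change directly. A modest downward step in this assay seems plausible, because compound 1 gives 0% and shows that moving away from compound 3 can remove the effect entirely. Compound 4 is expected to give about 35%, with a likely range from 5% to 65%. The expected step is a number 11 percentage points lower from compound 3 to compound 4 (beyond the scatter).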

Compound 4, a percentage reported as inhibition, in the whole organism at one dose (the size of the read-out at that dose, not a potency): 22%
Beside the measured number, compound 4's estimate is 13 percentage points above it; the range from low to high includes it.
By their numbers in this assay, from the lowest: compound 1; then compound 4; then compound 3; then compound 2.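

In this assay, putting (methylcarbamoyl)amino in place of aminomethyl on this aromatic carbon gives a number 24 percentage points lower from compound 3 to compound 4 (beyond the scatter). The position therefore accepts a group with more heavy atoms and a carbonyl, and compound 4 at 22% still shows some inhibition, though less than compound 3. No measured evidence accounts for this drop. As far as these compounds go, how an acetylamino group or a longer aminoethyl chain would read at this carbon stays open. Also open, from the compounds shown here alone, is whether this step would keep its size with a chlorine on the benzyl ring, as in compound 2.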